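Brominated diaryl ethers: propargyl to acetyl on the phenolic oxygen

The compounds below may be only part of what the source reports. "The series", "measured", "known", "first", "only" and "open" are said of these compounds alone.

Working notes on two bromophenyl ethers. Compound 2 `C#CCOc1c(Br)cc(Br)cc1Oc1ccc(Br)cc1Br` gives 29.7 ug/mL in a functional assay on HL-60 cells (Homo sapiens) for cytotoxicity, read by MTT assay, with a stated time of 24 h; on this read-out lower numbers stand for stronger inhibition and higher numbers for weaker inhibition; compound 1 `CC(C)(C)OC(=O)N1CCCN(CCCCCOc2c(Br)cc(Br)cc2Oc2ccc(Br)cc2Br)CC1` gives 44.8 ug/mL in this assay, and the two values sit within the scatter of each other. Compound 3 `CC(=O)Oc1c(Br)cc(Br)cc1Oc1ccc(Br)cc1Br` is not yet measured. Its change from compound 2 is acetyl in place of propargyl on an oxygen on an aromatic ring. For the measured compounds named here, no step between measured compounds is available to guide this, so the step of a 1.2-fold higher number from compound 2 to compound 3 (0.07 log units; within the scatter) is expected to be small, with no clear direction beyond the scatter. For compound 3 the estimate in this assay is 35 ug/mL, with a range from 15 ug/mL to 80 ug/mL.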

Compound 3, half-maximal inhibitory concentration: 29.9 ug/mL
Compound 3: the middle estimate sits 1.2-fold (0.07 log units) above what was measured; the measured number falls inside the stated range.
By their numbers in this assay, from the lowest: compounds 2, 3 and 1 (each within the scatter of the next).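

For the compounds shown here, on the oxygen on an aromatic ring, the change from propargyl to acetyl gives the first step that can be read at this position: a 1.0-fold higher number from compound 2 to compound 3 (0.00 log units; within the scatter) in this assay. A triple bond outside aromatic rings gives way to a double bond and a hydrogen-bond acceptor enters, yet this read-out does not separate the two groups. No measurement shown bears on this result.

Open, going by these compounds, is whether a free hydroxyl or a carboxylic acid on this oxygen would give a step beyond the scatter. Also open, on these data alone, is whether the bromine atoms of the shared core matter, since all three compounds carry the same pattern.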